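From 2-bromobenzyl to (furan-2-yl)methyl: working notes

The source may hold more compounds than are shown below. What is called first, only, known or untested is meant among the compounds shown, and "the series" means these compounds.

- compound 1 (`Cc1cc(=O)c2c(O)cc(OCc3ccccc3)c([C@H]3CCN(C)C[C@H]3O)c2o1`): 14%
- compound 2 (`Cc1cc(=O)c2c(O)cc(OCc3ccccc3Br)c([C@H]3CCN(C)C[C@H]3O)c2o1`): 30%

In a functional assay on MIA PaCa-2 cells (Homo sapiens) for inhibition, read by MTT assay, with a stated time of 48 h, tested at 10 uM (a lower number here means less inhibition of growth, a higher number more inhibition of growth at the concentration tested), compound 2 stands highest of the two measured compounds, with 30% as its value. The next compound, compound 3 (`Cc1cc(=O)c2c(O)cc(OCc3ccco3)c([C@H]3CCN(C)C[C@H]3O)c2o1`), has furan-2-yl in place of 2-bromophenyl on a saturated chain carbon bound to an oxygen on an aromatic ring. The same difference reads as 2-bromobenzyl to (furan-2-yl)methyl.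

Within the data shown here, the only measured step that bears on this is a number 16 percentage points higher from compound 1 to compound 2 (beyond the scatter) (bromo in place of hydrogen on an aromatic carbon), which is modest but beyond the scatter. Compound 3 has no bromine, so the gain from that step is not expected to carry over. Among the measured compounds shown here, no measured compound has a five-membered aromatic ring, and the data cannot say how furan-2-yl compares with the unsubstituted ring. The working expectation is a return towards compound 1 (14%). The expected change is a number 14 percentage points lower from compound 2 to compound 3 (beyond the scatter) (a modest fall, similar in size to the measured step). The estimated value for compound 3 is 16% (expected range 5% to 28%).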

Compound 3, percent growth inhibition at one concentration: 7%
Compound 3: the middle estimate sits 9 percentage points above what was measured, and the stated range covers the measured number.
By their numbers in this assay, from the lowest: compounds 3 and 1 (each within the scatter of the next); then compound 2.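

In this assay the exchange of 2-bromophenyl for furan-2-yl, on a saturated chain carbon bound to an oxygen on an aromatic ring, gives a number 23 percentage points lower from compound 2 to compound 3 (beyond the scatter) and so does not hold the higher number of compound 2. The second reading, a number 7 percentage points lower from compound 1 to compound 3 (within the scatter) for furan-2-yl in place of phenyl, shows that the five-membered aromatic ring with one hetero atom and the unsubstituted phenyl cannot be told apart in this read-out, which leaves compound 2 alone above the other two of these three compounds. Nothing at hand bears on why 2-bromobenzyl stands apart, and no cause can be given for either step.

On these data alone, it remains open whether the higher number of compound 2 is tied to bromine specifically or would also appear with chlorine or a methoxy group in its place on the benzyl ring. Also open, as far as these compounds go, is whether any five- or six-membered ring at this position can exceed the phenyl and furan-2-yl level without a halogen, for example pyridin-2-yl or a furan-2-yl ring carrying bromine, or a longer chain between the oxygen and the ring.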